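The source may hold more compounds than are shown below. What is called first, only, known or untested is meant among the compounds shown, and "the series" means these compounds.

Compound 1 `CC(C)(C)c1csc(N)c1C(=O)c1ccc(Cl)cc1`: 1%
Compound 2 `Cc1sc(N)c(C(=O)c2ccc(Cl)cc2)c1-c1ccccc1`: 1%
Compound 3 `CC(C)(C)Cc1c(-c2ccccn2)sc(N)c1C(=O)c1ccc(Cl)cc1`: 1%

All three were read in an assay on CHO cells for displacement of a labelled ligand from adenosine receptor A3 (Homo sapiens), read by scintillation counting, tested at 10 uM; a lower number here means less inhibition, a higher number more inhibition at the concentration tested (going by the name of the read-out). Compound 3 stands level with compounds 1 and 2 at the digits shown; its nearest neighbour is compound 1 and its furthest compound 2, and neither gap reaches beyond the scatter. Nothing in the three values separates one substituent pattern on the shared core from another.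

Compound 4 `CC(C)(C)Cc1c(-c2ccc(Cl)c(Cl)c2)sc(N)c1C(=O)c1ccc(Cl)cc1` is not yet measured. Against compound 3 the change is 3,4-dichlorophenyl in place of pyridin-2-yl on an aromatic carbon. Within the data shown here, no step between measured compounds is known, so the size of this change in this assay has no precedent; with compounds 1, 2 and 3 all level, no step beyond the scatter is expected in either direction. Compound 4 is expected to give 3%, with a range from -5% to 15%. That estimate means an expected step of a number 2 percentage points higher from compound 3 to compound 4 (within the scatter).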

Compound 4, a percentage reported as inhibition, at one concentration (the size of the read-out at that concentration, not a potency): 1%
Compound 4: the middle estimate sits 2 percentage points above what was measured; measured number inside the range.
By their numbers in this assay, from the lowest: compounds 1, 2, 3 and 4 (each within the scatter of the next).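

On the aromatic carbon next to the ring sulfur, the series now has its first readable step: in this assay, 3,4-dichlorophenyl in place of pyridin-2-yl gives no change at the digits printed from compound 3 to compound 4 (within the scatter) at this position. Exchanging a ring with one hydrogen-bond acceptor for a carbon-only ring bearing two chlorines therefore leaves the reading within the scatter. No supporting data bear on this outcome.

As far as these compounds go, it remains open whether a carboxylic acid or a dimethylamino group on this aromatic ring would move the reading. A longer chain in place of the neopentyl group is equally untested by these values.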